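Furan to pyrazole: a small heteroaryl exchange

This account rests on a few compounds, and the source may have more. Where it says the series, first, only, none or still open, it means among the compounds named here.

Measured compounds:
- Compound 1, `NS(=O)(=O)c1ccc(-c2nc(C(c3ccc(F)cc3)c3ccc(F)cc3)sc2CC(=O)O)cc1`, reaches only a limit in an in vitro functional assay on HEK285-7 cells for antagonist activity at prostaglandin D2 receptor 2 (Homo sapiens), read by BRET and beta-arrestin recruitment (on this read-out higher numbers stand for weaker inhibition and lower numbers for stronger inhibition), where compound 1 gives > 100000 nM.
- Compound 2, `CS(=O)(=O)Nc1cccc(-c2nc(C(c3ccc(F)cc3)c3ccc(F)cc3)sc2CC(=O)O)c1`, gives 370 nM in this assay.
- Compound 3, `O=C(O)Cc1sc(C(c2ccc(F)cc2)c2ccc(F)cc2)nc1-c1ccoc1`, gives 130 nM in this assay.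

Among the numbers shown, compound 3 has the lowest; its nearest neighbour is compound 2, separated by a 2.8-fold lower number from compound 2 to compound 3 (0.45 log units; beyond the scatter). Compound 1 sits at a limit, (the limit of > 100000 nM in this assay, at which 1 of the 3 values shown sits).

Compound 4, `O=C(O)Cc1sc(C(c2ccc(F)cc2)c2ccc(F)cc2)nc1-c1cn[nH]c1`, differs from compound 3 by 1H-pyrazol-4-yl in place of furan-3-yl on an aromatic carbon. Both measured steps that end at compound 3 change the same aromatic carbon: an at least 760-fold lower number from compound 1 to compound 3 (2.88 log units; beyond the scatter) and a 2.8-fold lower number from compound 2 to compound 3 (0.45 log units; beyond the scatter). Within the data shown here, both replaced a substituted phenyl by a small five-membered heteroaryl; neither tests a second small heteroaryl against the furan, so the pyrazole change has no direct precedent here. The change keeps the ring size and adds a hydrogen-bond donor, as counted above. No step beyond the scatter is expected in this assay, with a mild rise as the more likely direction. This amounts to an expected step of a 1.9-fold higher number from compound 3 to compound 4 (0.28 log units; within the scatter). Compound 4 is therefore estimated at 250 nM, with a range from 60 nM to 1500 nM.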

Compound 4, half-maximal inhibitory concentration: 220 nM
Compound 4: middle estimate off by 1.1-fold (0.06 log units), on the high side, and the stated range covers the measured number.
By their numbers in this assay, from the lowest: compounds 3, 4 and 2 (each within the scatter of the next, the first and the last beyond it). At a limit, above all of these: compound 1.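

In this assay, setting 1H-pyrazol-4-yl in place of furan-3-yl on this aromatic carbon, which brings in a hydrogen-bond donor, gives a 1.7-fold higher number from compound 3 to compound 4 (0.23 log units; within the scatter), so the position takes a second small five-membered heteroaryl without a step that can be told from the scatter. The comparison with the substituted phenyls divides: a 1.7-fold lower number from compound 2 to compound 4 (0.23 log units; within the scatter), so the pyrazole does not separate from the 3-(methanesulfonamido)phenyl group as the furan did, while the other comparison gives an at least 450-fold lower number from compound 1 to compound 4 (2.65 log units; beyond the scatter). That last step has only a bound, as compound 1 stands at a limit: the limit of > 100000 nM in this assay, at which 1 of the 4 values shown sits.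

On these data alone, whether the hydrogen on the pyrazole nitrogen plays any part stays open, and a methyl group on that nitrogen would test it. Also open, as far as these compounds go, is whether an unsubstituted phenyl or a thiophene ring at this carbon would fall with the five-membered heteroaryls or with the substituted phenyls.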